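The source may report more compounds than this note shows. Statements on the series, on what has been measured and on what is new or still open speak of the compounds shown alone.

Measured so far:
compound 1 `CCOC(=O)C1=C(C)NC(C)=C(C(=O)OCC)C1c1ccc(OCC(=O)Nc2ccc(C)cc2)cc1` — 62.2%
compound 2 `CCOC(=O)C1=C(C)NC(C)=C(C(=O)OCC)C1c1ccc(OCC(=O)NNC(=O)c2ccc(C)cc2)cc1` — 46.7%

In a functional assay on the whole organism (strain Wistar) for inhibition, with Rattus norvegicus as the target, read by paw edema, with stated times of 30 min and 2 h, at a dose of 20 mg/kg (a lower number here means less inhibition, a higher number more inhibition at the dose given (going by the name of the read-out)), compound 2 gives 46.7%, the lowest of the two numbers. Going by the values given here, compound 1 gives 62.2%, and the one measured step, a number 15.5 percentage points lower from compound 1 to compound 2 (beyond the scatter), comes from ((4-methylphenyl)carbonyl)amino replacing 4-methylphenyl on the amide-type nitrogen.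

Compound 3 `CCOC(=O)C1=C(C)NC(C)=C(C(=O)OCC)C1c1ccc(OCC(=O)NNC(=O)c2sccc2Cl)cc1` differs from compound 2 at a different place: 3-chlorothiophen-2-yl in place of 4-methylphenyl on a carbonyl carbon. Among the compounds with values here, no measured step alters the group on this carbonyl carbon, so the one step gives only a weak guide. Compound 3 is therefore expected to stay close to compound 2, with no step beyond the scatter: a number 1.7 percentage points lower from compound 2 to compound 3 (within the scatter). For compound 3 the estimate is 45%, between 30% and 60%.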

Compound 3, a percentage reported as inhibition, in the whole organism at one dose (the size of the read-out at that dose, not a potency): 57.2%
Compound 3: the middle estimate sits 12.2 percentage points below what was measured, and the stated range covers the measured number.
By their numbers in this assay, from the lowest: compound 2; then compounds 3 and 1 (each within the scatter of the next).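

On the carbonyl carbon, 3-chlorothiophen-2-yl in place of 4-methylphenyl gives a number 10.5 percentage points higher from compound 2 to compound 3 (beyond the scatter) in this assay and so shows that the group at this place can move the result. On the amide-type nitrogen, ((3-chlorothiophen-2-yl)carbonyl)amino in place of 4-methylphenyl gives a number 5 percentage points lower from compound 1 to compound 3 (within the scatter) and so, unlike ((4-methylphenyl)carbonyl)amino, shows no loss beyond the scatter. No measurement is available that would explain either step. Whether the chlorine or the thiophene ring accounts for the step from 4-methylphenyl remains open, and thiophen-2-yl or 4-chlorophenyl on the same carbonyl carbon would separate the two.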